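The compounds below may be only part of what the source reports. "The series", "measured", "known", "first", "only" and "open" are said of these compounds alone.

The measured compounds so far:

compound 1, `Cc1ccccc1-c1nnc(SCCn2c([N+](=O)[O-])cnc2C)o1`: 32300 nM
compound 2, `COc1ccc(-c2nnc(SCCn3c([N+](=O)[O-])cnc3C)o2)c(O)c1`: 11700 nM
compound 3, `COc1cc(-c2nnc(SCCn3c([N+](=O)[O-])cnc3C)o2)cc(OC)c1OC`: 34800 nM

Of the compounds shown here, three built on a shared core have been tested in a functional assay on SGC-7901 cells (Homo sapiens) for cytotoxicity, read by MTT assay, with a stated time of 48 h; on this read-out lower numbers stand for stronger inhibition and higher numbers for weaker inhibition. Within this set compound 1 gives the second highest number. Its nearest neighbour is compound 3, whose number lies within the usual scatter of repeated measurements, so the two cannot be told apart on the numbers alone. Compound 2 gives the lowest number of the three, and its gap to compound 1 lies beyond the scatter. No two of these compounds differ from each other in a single place, so none of the gaps between them can be tied to one structural change.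

Compound 4, `Cc1ncc([N+](=O)[O-])n1CCSc1nnc(-c2ccccn2)o1`, has not yet been measured in this assay. It differs from compound 1 in one place: pyridin-2-yl in place of 2-methylphenyl on an aromatic carbon. Going by the values given here, the measured set holds no example of such a change on this core, so there is no basis for expecting a large move in either direction. The step is estimated to be modest and toward a lower number, quite possibly staying within the scatter: a 1.3-fold lower number from compound 1 to compound 4 (0.11 log units; within the scatter). For compound 4 the expected value in this assay is 25000 nM, with a range from 8000 nM to 70000 nM.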

Compound 4, half-maximal inhibitory concentration: 30000 nM
Compound 4: middle estimate off by 1.2-fold (0.08 log units), on the low side, and the stated range covers the measured number.
By their numbers in this assay, from the lowest: compound 2; then compounds 4, 1 and 3 (each within the scatter of the next).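

In this assay, the shared core now gives its first comparison that differs in one place: a 1.1-fold lower number from compound 1 to compound 4 (0.03 log units; within the scatter) when pyridin-2-yl replaces 2-methylphenyl on the aromatic carbon next to the ring nitrogen and next to the ring oxygen. Going by these compounds alone, at this position, a ring with one hetero atom and one hydrogen-bond acceptor can therefore take the place of a ring of carbon only, and the two compounds cannot be told apart on their numbers, a direct reading that the earlier compounds could not give. Nothing measured here accounts for this result, so it stands as an observation without an explanation.

Whether this position responds to a more drastic change remains open, as every group shown there is a six-membered aromatic ring. A cyclohexyl group, a morpholine or a simple amine in that place, or a carboxylic acid on the ring, could still shift the number beyond the scatter or leave it unchanged.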